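The source may hold more compounds than are shown below. What is called first, only, known or untested is meant among the compounds shown, and "the series" means these compounds.

For the measured compounds named here, compound 3 `COc1ccc2c(=O)c(/C=C/C(=O)Nc3cc(C)ccc3C)coc2c1` is one of three compounds tested so far in a functional assay on L02 cells (Homo sapiens) for inhibition, read by MTT assay, with a stated time of 48 h; a higher number here means a weaker inhibitor, a lower number a stronger inhibitor. In this assay compound 3 gives > 200000 nM, which is a limit of the assay rather than a measured number. Compound 1 `COc1ccc2c(=O)c(/C=C/C(=O)Nc3ccc(C)cc3)coc2c1` gives > 200000 nM in this assay, again a limit. Compound 2 `COc1ccc2c(=O)c(/C=C/C(=O)NCc3cccc(F)c3)coc2c1` gives > 200000 nM in this assay, also a limit. The three differ only in the group carried on the amide-type nitrogen, and the steps between them, a step that the two limits leave unreadable from compound 1 to compound 2, a step that the two limits leave unreadable from compound 1 to compound 3 and a step that the two limits leave unreadable from compound 2 to compound 3, cannot be read: both ends of each sit at a limit. Going by the values given here, the one firm observation is the limit of > 200000 nM in this assay, at which 3 of the 3 values shown sit, shared by every compound measured so far.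

Compound 4 `COc1ccc2c(=O)c(/C=C/C(=O)Nc3ccccc3)coc2c1` is the next to be measured. It differs from compound 3 as follows: phenyl in place of 2,5-dimethylphenyl on an amide-type nitrogen. Because the three measured compounds all sit at the limit of > 200000 nM in this assay, at which 3 of the 3 values shown sit, nothing readable shows that changing the group on the amide-type nitrogen moves the value in either direction, and compound 4 is therefore expected to remain at the limit too. The expected step that the limit leaves unreadable from compound 3 to compound 4 is accordingly no real change. For compound 4 the estimate in this assay is 300000 nM, with a range from 100000 nM to 1000000 nM, most likely reported again only as a limit.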

Compound 4, half-maximal inhibitory concentration: > 200000 nM
Compound 4: only a limit was reported (the forecaster's own chance of this, stated with the estimate: 85%); the middle value does not contradict the limit.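

Compound 4 gives > 200000 nM in this assay, again a limit of the assay and not a number. Its steps to compound 1, compound 2 and compound 3 therefore cannot be read, as all four compounds share one limit: the limit of > 200000 nM in this assay, at which 4 of the 4 values shown sit. The compounds shown leave open whether any group on the amide-type nitrogen would give a readable value in this assay.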